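Sulfonamide chain variation on a pyrazolyl-bearing core

A few compounds are considered here, and "the series" means these few. Any claim that something is new, unique, unknown or untested is made for them only; others in the source may bear on it.

Measured so far in a functional assay on Huh-7 cells (Homo sapiens) for antiproliferative activity, read by CCK-8 assay, with a stated time of 72 h; on this read-out lower numbers stand for stronger inhibition of growth and higher numbers for weaker inhibition of growth:
- compound 1 `CCCNS(=O)(=O)c1ccc(Nc2ncc3c(n2)N(C2CCCC2)[C@H](CC)C(=O)N3C)cc1`: 278 nM
- compound 2 `CCC1C(=O)N(C)c2cnc(-n3ccc4cc(C(=O)NC)ccc43)nc2N1c1ccn(C)n1`: 13200 nM
- compound 3 `CCC1C(=O)N(C)c2cnc(Nc3ccc(S(=O)(=O)NCCCO)cc3)nc2N1c1ccn(C)n1`: "not active" (no number reported)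

Compound 1 carries a propyl sulfonamide and a cyclopentyl group on the shared core and in this assay gives 278 nM. Compound 2, with the methylpyrazolyl group on the core and a different aryl portion, gives 13200 nM in this assay. Compound 3 keeps the methylpyrazolyl group and carries a 3-hydroxypropyl sulfonamide; in this assay compound 3 is reported as "not active" (no number reported), so no number stands for it and its place on the scale is open. It can only be said that compound 3 did not reach a measurable result where compound 1 and compound 2 did.

Compound 4 `CCCCNS(=O)(=O)c1ccc(Nc2ncc3c(n2)N(c2ccn(C)n2)C(CC)C(=O)N3C)cc1` is not yet measured. It differs from compound 3 in one place: methyl in place of hydroxy on a saturated chain carbon, three bonds along the chain from a sulfonamide nitrogen. Among the compounds with values here, no step between two measured compounds matches this change, so its size and direction in this assay are unknown. Given that compound 3 gives no number and compound 2, which shares the methylpyrazolyl group, gives 13200 nM, compound 4 is expected to land in the weak range, estimated at 6000 nM with a range of 1500 nM to 30000 nM, and it may well be that this assay again reports no number for it.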

Compound 4, concentration for 50% growth inhibition: 3750 nM
Compound 4: middle estimate off by 1.6-fold (0.20 log units), on the high side; the range from low to high includes it.
By their numbers in this assay, from the lowest: compound 1; then compound 4; then compound 2.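

Within the data shown here, compound 3 is reported as without a number in this assay and compound 4 gives 3750 nM there, so no step from compound 3 to compound 4 can be read. The compounds shown leave open how far 3-hydroxypropyl to butyl on the sulfonamide moves growth inhibition, and in which direction. No measurement shown here bears on this result.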